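Amine side-chain series in the mouse electroshock screen

This account rests on a few compounds, and the source may have more. Where it says the series, first, only, none or still open, it means among the compounds named here.

Measured so far:
compound 1 `CN(C)CCCOc1ccccc1/C=C/c1ccccc1`: 14.2%
compound 2 `CN(C)CCCCOc1ccccc1/C=C/c1ccc(Cl)cc1`: 0%
compound 3 `CN(C)CCCCOc1cccc(/C=C/c2ccccc2)c1`: 0%

In a functional assay on the whole organism with Mus musculus as the target, in the maximal electroshock model, at a dose of 50 mg/kg by the oral route (on this read-out higher numbers stand for more inhibition at the one dose given (going by the name of the read-out) and lower numbers for less inhibition), compound 1 gives 14.2%, the highest of the three numbers. Compound 2 gives 0% and compound 3 gives 0%; each of these lies below compound 1 by an amount beyond the usual scatter, and the two are equal to each other. Going by the values given here, no two measured compounds differ in only one place, so no measured step can be used to size the change considered next.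

Compound 4 `C(=C/c1ccccc1OCCCCN1CCNCC1)\c1ccccc1` has not been measured. Compared with compound 1 the difference is: (piperazin-1-yl)methyl in place of dimethylamino on a saturated chain carbon, three bonds along the chain from an oxygen on an aromatic ring. Among the compounds with values here, nothing among the measured compounds shows what this change does, and all three measured numbers are low. The step is therefore expected to be small, a number 4.2 percentage points lower from compound 1 to compound 4 (within the scatter), not beyond the scatter in either direction. For compound 4 the expected result in this assay is 10%, with a range from 0% to 35%.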

Compound 4, a percentage reported as inhibition, in the whole organism at one dose (the size of the read-out at that dose, not a potency): 0%
Compound 4: the middle estimate sits 10 percentage points above what was measured; the range from low to high includes it.
By their numbers in this assay, from the lowest: compounds 2, 3 and 4 (each within the scatter of the next); then compound 1.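

In this assay, going by these compounds alone, the change to (piperazin-1-yl)methyl in place of dimethylamino on a saturated chain carbon, three bonds along the chain from an oxygen on an aromatic ring, gives a number 14.2 percentage points lower from compound 1 to compound 4 (beyond the scatter) and so provides the first readable step. At this position, the larger group with its six-membered non-aromatic ring and hydrogen-bond donor does not retain the small response seen with dimethylamino. Nothing available explains this step.

The same difference also reads (dimethylamino)methyl to 2-(piperazin-1-yl)ethyl, so the ring and the chain are not separated by this pair. A morpholine or piperidine at the end of the chain, or dimethylamino on the chain of compound 4, would show which part of the change carries the step.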